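Swapping a pyridyl amide for a methylthiazolyl amide

The source may hold more compounds than are shown below. What is called first, only, known or untested is meant among the compounds shown, and "the series" means these compounds.

Compound 1 `CCCCNc1nc(N)nc2c1CN(C(C)=O)CC2` carries an acetyl group on the ring nitrogen of the shared core. In an assay on HEK293 cells for agonist activity at Toll-like receptor 8 (Homo sapiens), read by a luciferase reporter, with a stated time of 6 h (a higher number here means that more compound is needed for the effect, a lower number that less compound is needed), compound 1 gives 0.5 uM. Compound 2 `CCCCNc1nc(N)nc2c1CN(C(=O)c1ccncc1)CC2` differs from it only in that a pyridin-4-yl replaces the methyl on the carbonyl carbon. In this assay compound 2 reaches only a limit of the assay, > 25 uM. The step of an at least 50-fold higher number from compound 1 to compound 2 (1.69 log units; beyond the scatter) is therefore large, and compound 2 stands at the limit of > 25 uM in this assay, at which 1 of the 2 values shown sits.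

Compound 3 `CCCCNc1nc(N)nc2c1CN(C(=O)c1csc(C)n1)CC2` is the next step from compound 2: 2-methyl-1,3-thiazol-4-yl in place of pyridin-4-yl on a carbonyl carbon. For the measured compounds named here, only one measured step bears on this change, namely an at least 50-fold higher number from compound 1 to compound 2 (1.69 log units; beyond the scatter), which shows that putting a six-membered aromatic ring in place of a methyl on that carbonyl carbon moved the number far upward. Going by the values given here, compound 3 keeps an aromatic ring in that place, and no measured pair with a five-membered ring there exists. For compound 3 the step of a number no higher from compound 2 to compound 3 (the limit leaves the size open) is expected to be none beyond the scatter. Compound 3 is estimated at 25 uM, with a range from 5 uM to 60 uM, and a further limit reading is the likelier outcome.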

Compound 3, minimum effective concentration: 1.8 uM
The estimate for compound 3 lay 14-fold (1.14 log units) above the measured number; the measured number lies below the stated range.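

In this assay, an aromatic ring on this carbonyl carbon does not by itself carry the number up to the limit of the assay: the change from pyridin-4-yl to 2-methyl-1,3-thiazol-4-yl gives an at least 13-fold lower number from compound 2 to compound 3 (1.14 log units; beyond the scatter). Set against the acetyl group, the 2-methyl-1,3-thiazol-4-yl group leaves only a 3.6-fold higher number from compound 1 to compound 3 (0.56 log units; beyond the scatter), a far smaller rise than an at least 50-fold higher number from compound 1 to compound 2 (1.69 log units; beyond the scatter), so at this place the identity of the aromatic ring matters and not just its presence. Compound 2 stands at a limit of the assay, so the full size of its step to compound 3 cannot be read: the limit of > 25 uM in this assay, at which 1 of the 3 values shown sits.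

The change from pyridin-4-yl to 2-methyl-1,3-thiazol-4-yl alters the ring size, the hetero atoms and the methyl group all at once, and the compounds shown do not tell these apart. On these data alone, it remains open how an unsubstituted 1,3-thiazol-4-yl, a phenyl or a furan-2-yl on the same carbonyl carbon would read, and whether any aromatic group there can match or go lower than the number of compound 1.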